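Changing the aryl amine: from compound 2 to compound 4

This account rests on a few compounds, and the source may have more. Where it says the series, first, only, none or still open, it means among the compounds named here.

Compound 1 `Cc1cc(F)cc(Nc2cc(NC(=O)Nc3c(Cl)cccc3Cl)ncn2)c1`: 78.1%
Compound 2 `COc1cc(NC(=O)Nc2cc(Nc3cccc(C(C)(C)C)c3)ncn2)cc(OC)c1`: 40%
Compound 3 `COc1cc(Nc2cc(NC(=O)Nc3c(Cl)cccc3Cl)ncn2)cc(OC)c1`: 60%

Three compounds with a shared core were tested in a functional assay on NCI-H226 cells (Homo sapiens) for inhibition, read by MTT assay, with a stated time of 48 h, tested at 10 uM; a higher number here means more inhibition at the concentration tested (going by the name of the read-out), a lower number less inhibition. Compound 2 stands lowest of the three numbers; the nearest is compound 3, whose value lies higher by a gap beyond the usual scatter, and the furthest is compound 1, higher still. No pair of these compounds differs in a single place, so no measured step isolates any one change.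

Compound 4 `COc1cc(NC(=O)Nc2cc(Nc3cc(Br)ccc3OC)ncn2)cc(OC)c1` has not yet been measured in this assay. It keeps the urea side of compound 2 and alters the amine side: 5-bromo-2-methoxyphenyl in place of 3-(tert-butyl)phenyl on a nitrogen on an aromatic ring. Among the compounds with values here, no measured pair shows this change, so its effect is unknown. Within the data shown here, compound 2 is the only measured compound carrying the 3-(tert-butyl)phenyl group, and its value 40% is the lowest seen, which is the sole basis for expecting a move upward rather than downward. For compound 4 the expected step of a number 10 percentage points higher from compound 2 to compound 4 (within the scatter) is modest, possibly within the scatter. Compound 4 is estimated at 50%, with a range from 25% to 75%.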

Compound 4, a percentage reported as inhibition, at one concentration (the size of the read-out at that concentration, not a potency): 42.7%
Compound 4: the middle estimate sits 7.3 percentage points above what was measured; measured number inside the range.
By their numbers in this assay, from the lowest: compounds 2 and 4 (each within the scatter of the next); then compound 3; then compound 1.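

Replacing 3-(tert-butyl)phenyl with 5-bromo-2-methoxyphenyl on a nitrogen on an aromatic ring, with the urea side held fixed, gives a number 2.7 percentage points higher from compound 2 to compound 4 (within the scatter) in this assay. Within the data shown here, this is the first single-place change seen at this position, and it shows that these two groups cannot be told apart in this read-out, even though the entering group brings an oxygen and a bromine where the leaving group has only carbon. The low number of compound 2 therefore cannot be pinned on the 3-(tert-butyl)phenyl group, and nothing available explains why the two groups match.

From the compounds shown here alone, whether the same exchange would also leave the number in place with the urea side of compound 1 remains open. So does whether a carboxylic acid or a morpholine on the aromatic ring at this position would shift the number beyond the scatter.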